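Compound 4: One Chain Step Beyond a Limit

The source may hold more compounds than are shown below. What is called first, only, known or untested is meant among the compounds shown, and "the series" means these compounds.

In a functional assay on FaDu cells (Homo sapiens) for antiproliferative activity, read by sulforhodamine B assay, with a stated time of 48 h (on this read-out higher numbers stand for weaker inhibition and lower numbers for stronger inhibition), compound 1 (`CCCCN(C)C(=O)CCCOc1cc(OC)c(OC)c2oc(-c3ccc(OC)cc3)c(O)c(=O)c12`) gives > 40000 nM, which is a limit and not a number. Compound 2 (`COc1ccc(-c2oc3c(OC)c(OC)cc(OCCCC(=O)N4CCN(C)CC4)c3c(=O)c2O)cc1`) gives > 40000 nM, also a limit. Compound 3 (`COc1ccc(-c2oc3c(OC)c(OC)cc(OCCCCC(=O)N4CCN(C)CC4)c3c(=O)c2O)cc1`) gives > 40000 nM, again only a limit. All three therefore stand together at the limit of > 40000 nM in this assay, at which 3 of the 3 values shown sit.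

Compound 4 (`COc1ccc(-c2oc3c(OC)c(OC)cc(OCCCCCC(=O)N4CCN(C)CC4)c3c(=O)c2O)cc1`) carries ((4-methylpiperazin-1-yl)carbonyl)methyl in place of (4-methylpiperazin-1-yl)carbonyl on a saturated chain carbon, four bonds along the chain from an oxygen on an aromatic ring.

The closest guide is the same replacement made three bonds along the chain, a step that the two limits leave unreadable from compound 2 to compound 3. The other measured steps, a step that the two limits leave unreadable from compound 1 to compound 2 and a step that the two limits leave unreadable from compound 1 to compound 3, give no size either.

In this assay, a number no higher from compound 3 to compound 4 (the limit leaves the size open) is expected to stay within the usual scatter, with no direction foreseen, and another limit is the likeliest report. For compound 4 the estimated value is 40000 nM, with an expected range from 15000 nM to 80000 nM.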

Compound 4, half-maximal inhibitory concentration: 15800 nM
For compound 4 the middle estimate is 2.5-fold (0.40 log units) above the measured one; the range from low to high includes it.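

In this assay, within the data shown here, the longer chain gives the first readable number: there is an at least 2.5-fold lower number from compound 3 to compound 4 (0.40 log units; beyond the scatter), an at least 2.5-fold lower number from compound 2 to compound 4 (0.40 log units; beyond the scatter), and, with butyl(methyl)carbamoyl replaced as well, an at least 2.5-fold lower number from compound 1 to compound 4 (0.40 log units; beyond the scatter). Each size is only a minimum, and the steps among compound 1, compound 2 and compound 3 cannot be read. Only compound 4 gets past the limit that holds the other three: the limit of > 40000 nM in this assay, at which 3 of the 4 values shown sit.

Still open, from the compounds shown here alone, is whether a longer chain would lower the number further. Going by these compounds, it is also open whether a carboxylic acid or butyl(methyl)carbamoyl at the end of this chain would do the same as the piperazine amide.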